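This account rests on a few compounds, and the source may have more. Where it says the series, first, only, none or still open, it means among the compounds named here.

Measured so far in a functional assay on HepG2 cells (Homo sapiens) for cytotoxicity, read by MTT assay, with a stated time of 72 h; a lower number here means a stronger inhibitor, a higher number a weaker inhibitor:
- Compound 1 `CN1CCN(c2ccc(Nc3ncc4nc(Nc5ccccc5)n(C5CCCCC5)c4n3)cc2)CC1`: > 5000 nM, a limit
- Compound 2 `Cc1cc(C)cc(-n2c(Nc3ccccc3)nc3cnc(Nc4ccc(N5CCN(C)CC5)cc4)nc32)c1`: > 5000 nM, a limit
- Compound 3 `OCCNc1ccc(Nc2ncc3nc(Nc4ccccc4)n(C4CCCC4)c3n2)cc1`: > 5000 nM, a limit

Compound 3 therefore has no exact number, only a limit, and the other two compounds stand the same way. Compound 4 `CC(=O)Nc1ccc(Nc2ncc3nc(Nc4ccccc4)n(C4CCCC4)c3n2)cc1` changes one group of compound 3: acetyl in place of 2-hydroxyethyl on a nitrogen on an aromatic ring. Acetyl takes the place of 2-hydroxyethyl on a nitrogen on an aromatic ring, so that (2-hydroxyethyl)amino becomes acetamido.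

For the measured compounds named here, only one measured step exists, a step that the two limits leave unreadable from compound 1 to compound 2. It concerns a different group, and it offers no size to carry over. The remaining guide is the limit of > 5000 nM in this assay, at which 3 of the 3 values shown sit. With no readable step, no shift in either direction can be expected beyond the scatter, and a further report of only a limit is the likeliest outcome in this assay. The estimated change is a step that the limit leaves unreadable from compound 3 to compound 4. If a number is reported, compound 4 is expected near 8000 nM, within an estimated range of 4000 nM to 20000 nM.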

Compound 4, half-maximal inhibitory concentration: > 5000 nM
Compound 4 gave a limit, no number; the forecaster's own chance of this, stated with the estimate: 80%; the middle value does not contradict the limit.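

In this assay, for the compounds shown here, compound 3 and compound 4 each give only a limit, so no step between them can be read: the limit of > 5000 nM in this assay, at which 4 of the 4 values shown sit.
The compounds shown leave open whether any change of group would give this assay a real number rather than a limit.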